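Dropping One Chlorine From the Dichlorophenyl Amide

The compounds below may be only part of what the source reports. "The series", "measured", "known", "first", "only" and "open" are said of these compounds alone.

Three measured compounds share one core and differ only in where two chloro groups sit on the phenyl ring of the amide. Compound 1 `COc1cc(/C=C/C(=O)c2cccc(NC(=O)c3ccc(Cl)c(Cl)c3)c2)ccc1O` carries a 3,4-dichlorophenyl; in a functional assay on SiHa cells (Homo sapiens) for inhibition (a lower number here means a stronger inhibitor, a higher number a weaker inhibitor), compound 1 gives 25.3 ug/mL. Compound 2 `COc1cc(/C=C/C(=O)c2cccc(NC(=O)c3cc(Cl)cc(Cl)c3)c2)ccc1O` gives 17.7 ug/mL, and compound 3 `COc1cc(/C=C/C(=O)c2cccc(NC(=O)c3ccc(Cl)cc3Cl)c2)ccc1O` gives 34.4 ug/mL. Compound 1 stands second highest of these three numbers, yet all three lie within the scatter of one another: a 1.4-fold lower number from compound 1 to compound 2 (0.16 log units; within the scatter), a 1.4-fold higher number from compound 1 to compound 3 (0.13 log units; within the scatter), and a 1.9-fold higher number from compound 2 to compound 3 (0.29 log units; within the scatter).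

Compound 4 `COc1cc(/C=C/C(=O)c2cccc(NC(=O)c3ccc(Cl)cc3)c2)ccc1O` differs from compound 1 by hydrogen in place of chloro on an aromatic carbon. Within the data shown here, none of the measured steps removes a chloro group; each only moves one, and each stays within the scatter. Those steps bear on the question only loosely, showing that the chlorine arrangement on this ring has made little difference among the measured compounds. The expected step is therefore a 1.1-fold higher number from compound 1 to compound 4 (0.04 log units; within the scatter), not clearly beyond the scatter. Compound 4 is estimated at 28 ug/mL, with a range from 13 ug/mL to 60 ug/mL.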

Compound 4, half-maximal inhibitory concentration: 2.3 ug/mL
The estimate for compound 4 lay 12-fold (1.09 log units) above the measured number; the measured number lies below the stated range.
By their numbers in this assay, from the lowest: compound 4; then compounds 2, 1 and 3 (each within the scatter of the next).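

The chlorine count on this ring matters far more than the chlorine arrangement. In this assay, replacing one chloro with hydrogen gives an 11-fold lower number from compound 1 to compound 4 (1.04 log units; beyond the scatter) and a 15-fold lower number from compound 3 to compound 4 (1.17 log units; beyond the scatter), while going from the 3,5-dichlorophenyl to the 4-chlorophenyl gives a 7.7-fold lower number from compound 2 to compound 4 (0.89 log units; beyond the scatter), so all three dichlorophenyl compounds lie beyond the scatter from compound 4. Nothing available here explains why losing one chloro has so large an effect.

From the compounds shown here alone, it remains open whether the remaining chloro contributes to this result, since a plain phenyl ring would test that directly. Going by these compounds, how a fluoro or methoxy group in place of that chloro would compare, and whether the gain would carry over to other cell lines, also remains unknown.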